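Nitro for methylsulfonyl on the aryl ring of the core

A few compounds are considered here, and "the series" means these few. Any claim that something is new, unique, unknown or untested is made for them only; others in the source may bear on it.

Measured so far:
compound 1 `Nc1nc(-c2cccc(C(F)(F)F)c2)nc2sc(CN3CCC(F)CC3)cc12` — 3030 nM
compound 2 `CS(=O)(=O)c1cccc(-c2nc(N)c3cc(CN4CCC(F)CC4)sc3n2)c1` — > 10000 nM

Going by the values given here, compound 1 is the only member with a number in an assay on CHO-K1 cells for antagonist activity at adenosine receptor A1 (Homo sapiens), read by a beta-galactosidase reporter, with stated times of 15 min and 6 h (a higher number here means a weaker inhibitor, a lower number a stronger inhibitor), and there compound 1 gives 3030 nM. Compound 2 sits only at a limit of this assay, reporting > 10000 nM. Among the compounds with values here, the one measured step, an at least 3.3-fold higher number from compound 1 to compound 2 (0.51 log units; beyond the scatter), thus has a size known only as a floor, and the limit of > 10000 nM in this assay, at which 1 of the 2 values shown sits, is the reason its true size stays open.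

Compound 3 `Nc1nc(-c2cccc([N+](=O)[O-])c2)nc2sc(CN3CCC(F)CC3)cc12` is compound 2 with one change: nitro in place of methylsulfonyl on an aromatic carbon. No measured step bears on this particular exchange; the only step shown, trifluoromethyl to methylsulfonyl, runs into the limit and gives no guide to where a nitro group lands. Compound 3 is therefore expected to remain weak in this assay, at or near the limit, with the step of an at least 1.2-fold lower number from compound 2 to compound 3 (0.09 log units; that floor lies within the scatter) carrying little weight. The estimate for compound 3 is 8000 nM, within 2000 nM to 30000 nM.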

Compound 3, inhibition constant: > 10000 nM
Compound 3: only a limit was reported; the forecaster's own chance of this, stated with the estimate: 45%; middle value at least 1.2-fold (0.09 log units) away from the limit.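

In this assay compound 3 reports > 10000 nM, which is a limit and not a number. Nitro in place of trifluoromethyl on this aromatic carbon gives an at least 3.3-fold higher number from compound 1 to compound 3 (0.51 log units; beyond the scatter), so methylsulfonyl, with an at least 3.3-fold higher number from compound 1 to compound 2 (0.51 log units; beyond the scatter), is no longer the only replacement of trifluoromethyl here with a floor beyond the scatter. The step between compound 2 and compound 3 cannot be read, and the true sizes of both steps from compound 1 stay open because of the limit: the limit of > 10000 nM in this assay, at which 2 of the 3 values shown sit.

Still open, on these data alone, is whether any replacement of trifluoromethyl at this position gives a lower number than compound 1 does. As far as these compounds go, it is also open whether an amine or a carboxylic acid on this aromatic carbon would give a number rather than a limit in this assay.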